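Pyridyl in Place of Hydroxymethylphenyl: Expected Cytotoxicity

A few compounds are considered here, and "the series" means these few. Any claim that something is new, unique, unknown or untested is made for them only; others in the source may bear on it.

Compound 1, `COc1cc(CC(O)c2ccc(-c3ccc(C#N)cc3)cc2)c([N+](=O)[O-])cc1OC`: 4700 nM
Compound 2, `COc1cc(CC(O)c2ccc(-c3ccc(CO)cc3)cc2)c([N+](=O)[O-])cc1OC`: > 244000 nM
Compound 3, `COc1cc(CC(O)c2ccc(-c3cccc(CO)c3)cc2)c([N+](=O)[O-])cc1OC`: 6000 nM

In an ADME assay on HeLa Rh cells (Homo sapiens) for cytotoxicity, read by microscopy (on this read-out lower numbers stand for higher toxicity in this test and higher numbers for lower toxicity in this test), compound 1 gives 4700 nM and compound 3 gives 6000 nM, two numbers that sit within the scatter of each other (a 1.3-fold higher number from compound 1 to compound 3 (0.11 log units; within the scatter)). For compound 2 only a limit is known, > 244000 nM, as noted in the limit of > 244000 nM in this assay, at which 1 of the 3 values shown sits. Among the numbers shown, compound 3 holds the higher one, though its gap to compound 1 is not beyond the scatter. The step from compound 2 to compound 3 was large (an at least 40-fold lower number from compound 2 to compound 3 (1.60 log units; beyond the scatter)), as was the step from compound 1 to compound 2 (an at least 51-fold higher number from compound 1 to compound 2 (1.71 log units; beyond the scatter)).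

Compound 4, `COc1cc(CC(O)c2ccc(-c3cccnc3)cc2)c([N+](=O)[O-])cc1OC`, differs from compound 3 by pyridin-3-yl in place of 3-(hydroxymethyl)phenyl on an aromatic carbon. Within the data shown here, no measured step exchanges an aryl group for a pyridyl, so the bearing steps are indirect: the change that kept the number within the scatter (a 1.3-fold higher number from compound 1 to compound 3 (0.11 log units; within the scatter)) and the large rise (an at least 40-fold lower number from compound 2 to compound 3 (1.60 log units; beyond the scatter)) both involve the same position on the outer ring. For compound 4 the expected step is a 1.3-fold higher number from compound 3 to compound 4 (0.12 log units; within the scatter), with the estimate 8000 nM and a range from 2000 nM to 60000 nM.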

Compound 4, half-maximal cytotoxic concentration: > 263000 nM
Compound 4: only a limit was reported; the forecaster's own chance of this, stated with the estimate: 15%; middle value at least 32-fold (1.51 log units) away from the limit.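

At this aromatic carbon, para to a large group, the outer ring can shift the number far toward lower toxicity in this test without any hydroxymethyl group: pyridin-3-yl gives an at least 43-fold higher number from compound 3 to compound 4 (1.64 log units; beyond the scatter), and in place of 4-cyanophenyl it gives an at least 55-fold higher number from compound 1 to compound 4 (1.74 log units; beyond the scatter). Until this result, 4-(hydroxymethyl)phenyl in compound 2 was the only group shown at this place to reach a limit, so that outcome is not confined to it. Compound 4 also has only a limit: the limit of > 263000 nM in this assay, at which 1 of the 4 values shown sits.

From the compounds shown here alone, the step between compound 2 and compound 4 joins two limits and cannot be read, so their order stays open. Also open, going by these compounds, is how the number would respond to pyridin-4-yl, or to an aminomethyl group on the outer ring.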